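Phenyl in place of butyl on the ring nitrogen

The source may hold more compounds than are shown below. What is called first, only, known or untested is meant among the compounds shown, and "the series" means these compounds.

Measured so far in a functional assay on A549 cells (Homo sapiens) for antiproliferative activity, read by trypan blue exclusion, with a stated time of 72 h, tested at 20 uM; a higher number here means more inhibition at the concentration tested (going by the name of the read-out), a lower number less inhibition:
compound 1, `CCCCN1C(=O)NC(=O)/C1=C/c1ccccc1`: 18%
compound 2, `CCCCN1C(=O)NC(=O)/C1=C/c1ccc(Cl)cc1`: 26%

Among the measured compounds shown here, compound 1 stands lowest of the two numbers in this assay, though the only measured step, a number 8 percentage points higher from compound 1 to compound 2 (within the scatter), lies within the scatter. Compound 3, `O=C1NC(=O)N(c2ccccc2)/C1=C\c1ccccc1`, differs from compound 1 by phenyl in place of butyl on an amide-type nitrogen in a ring. For the measured compounds named here, no measured step touches the amide-type nitrogen in the ring; the single known step concerns an aromatic carbon and stayed within the scatter. The account therefore expects no step beyond the scatter. Compound 3 is estimated at 22%, between 6% and 42%, a step of a number 4 percentage points higher from compound 1 to compound 3 (within the scatter) expected from compound 1.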

Compound 3, a percentage reported as inhibition, at one concentration (the size of the read-out at that concentration, not a potency): 26%
The estimate for compound 3 lay 4 percentage points below the measured number; measured number inside the range.
By their numbers in this assay, from the lowest: compounds 1, 2 and 3 (each within the scatter of the next).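

At the amide-type nitrogen in a ring, phenyl in place of butyl gives a number 8 percentage points higher from compound 1 to compound 3 (within the scatter) in this assay. This position now has a measured step of its own, and replacing an open chain with an aromatic ring there leaves the number within the scatter. No available evidence bears on this result.

The compounds shown leave open whether a longer chain than butyl, or a chain ending in an amine or a carboxylic acid, on that nitrogen would move the number beyond the scatter. They also leave open how chloro on the aromatic carbon would behave with phenyl on the nitrogen.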